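This account rests on a few compounds, and the source may have more. Where it says the series, first, only, none or still open, it means among the compounds named here.

Series of the shared core, all tested in an ADME assay on RAW264.7 cells (Mus musculus) for cytotoxicity, read by MTT assay, with a stated time of 24 h; a higher number here means that more compound is tolerated, a lower number that less compound is tolerated. Compound 1 `O=C1CSC(N2N=C(c3ccc(Cl)c(Cl)c3)CC2c2ccccc2)=N1` gives 295000 nM. Compound 3 `Cc1ccccc1C1CC(c2ccc(Cl)c(Cl)c2)=NN1C1=NC(=O)CS1` gives 179000 nM, the step of a 1.6-fold lower number from compound 1 to compound 3 (0.22 log units; within the scatter) being methyl in place of hydrogen on an aromatic carbon. Compound 2 `Cc1ccc(C2=NN(C3=NC(=O)CS3)C(c3ccccc3)C2)cc1C` is reported only as a limit of the assay, > 450000 nM, so its position is known only as a floor (the limit of > 450000 nM in this assay, at which 1 of the 3 values shown sits). The step of an at least 1.5-fold higher number from compound 1 to compound 2 (0.18 log units; that floor lies within the scatter) is 3,4-dimethylphenyl in place of 3,4-dichlorophenyl on a carbon with a double bond to nitrogen. Compound 4 `Cc1ccc(C2CC(c3ccc(C)c(C)c3)=NN2C2=NC(=O)CS2)cc1` is not yet measured; its change from compound 2 is methyl in place of hydrogen on an aromatic carbon. Among the compounds with values here, the one measured step of the same kind, a 1.6-fold lower number from compound 1 to compound 3 (0.22 log units; within the scatter), stayed within the scatter, so no step beyond the scatter is expected in this assay. Compound 4 is therefore estimated at 450000 nM, between 230000 nM and 900000 nM. The expected step is a number no higher from compound 2 to compound 4 (the limit leaves the size open).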

Compound 4, half-maximal cytotoxic concentration: 384000 nM
Compound 4: the middle estimate sits 1.2-fold (0.07 log units) above what was measured, and the stated range covers the measured number.
By their numbers in this assay, from the lowest: compounds 3, 1 and 4 (each within the scatter of the next, the first and the last beyond it). At a limit, above all of these: compound 2.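

In this assay, phenyl to 4-methylphenyl on the core of compound 2 gives an at least 1.1-fold lower number from compound 2 to compound 4 (0.06 log units; that floor lies within the scatter), so this methyl, para to a large group, can now be read on a second core. As far as these compounds go, compound 2, at > 450000 nM, remains a limit of the assay, and the true size of the step stays unknown. The two readings of the change cannot yet be separated: the same change on two cores in this assay, a 1.6-fold lower number (0.22 log units; within the scatter) from compound 1 to compound 3 and an at least 1.1-fold lower number (0.06 log units; that floor lies within the scatter) from compound 2 to compound 4; the limit leaves it open whether they differ

From the compounds shown here alone, whether an amine or a carboxylic acid in place of this methyl would leave the number in the same range remains open.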